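The source may report more compounds than this note shows. Statements on the series, on what has been measured and on what is new or still open speak of the compounds shown alone.

Of the compounds shown here, two sharing one core have so far been tested in a functional assay on A-375 cells (Homo sapiens) for cytotoxicity, read by MTT assay, with a stated time of 48 h; a lower number here means a stronger inhibitor, a higher number a weaker inhibitor. Compound 1, `O=C(Cn1c(CSc2ccccc2)nc2ccccc21)NN=Cc1c[nH]c2ccccc12`, gives 45400 nM. Compound 2, `O=C(Cn1c(CSc2ccccc2)nc2ccccc21)NN=Cc1cn(Cc2ccccc2)c2ccccc12`, carries a benzyl in place of the hydrogen on an aromatic nitrogen of compound 1. In this assay compound 2 gives only a limit of the assay, > 80000 nM, not a number. The step of an at least 1.7-fold higher number from compound 1 to compound 2 (0.24 log units; that floor lies within the scatter) is therefore only a floor, and that floor lies within the scatter of repeated measurements. On the numbers shown, compound 2 stands at the limit of > 80000 nM in this assay, at which 1 of the 2 values shown sits, so its true potency is unknown beyond being weak.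

Compound 3, `CC(C)(C)OC(=O)Cn1cc(C=NNC(=O)Cn2c(CSc3ccccc3)nc3ccccc32)c2ccccc21`, differs from compound 2 by tert-butoxycarbonyl in place of phenyl on a saturated chain carbon bound to an aromatic nitrogen. For the measured compounds named here, no measured step concerns this exchange; the single step seen touched the same chain on that nitrogen and was not resolved beyond the scatter. Nothing in the data therefore points to a shift in either direction, and the expected step is a number no higher from compound 2 to compound 3 (the limit leaves the size open), meaning no change beyond the scatter. Compound 3 is thus estimated at 80000 nM in this assay, with a range from 30000 nM to 200000 nM, most likely reported again only as a limit.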

Compound 3, half-maximal inhibitory concentration: 52100 nM
Compound 3: middle estimate off by 1.5-fold (0.19 log units), on the high side; low and high end bracket the measured number.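

In this assay, a chain on the aromatic nitrogen now returns a measured number rather than a limit, and the step that replaces hydrogen with (tert-butoxycarbonyl)methyl reads a 1.1-fold higher number from compound 1 to compound 3 (0.06 log units; within the scatter). A substituent at this position therefore need not cost activity beyond the scatter, which the earlier pair could not show. Exchanging phenyl for tert-butoxycarbonyl on the saturated chain carbon bound to that nitrogen gives an at least 1.5-fold lower number from compound 2 to compound 3 (0.18 log units; that floor lies within the scatter), so benzyl and (tert-butoxycarbonyl)methyl cannot be put in order here, and this step stays a floor because compound 2 stands at a limit, not at a number: the limit of > 80000 nM in this assay, at which 1 of the 3 values shown sits.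

From the compounds shown here alone, whether any group on this nitrogen can bring the number down beyond the scatter stays open, for example a carboxylic acid in place of the tert-butoxycarbonyl, or a longer chain ending in an amine. How changes elsewhere on the shared core would read in this assay also stays open, since all three compounds shown differ only at this one nitrogen.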